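Two Chlorines in Place of a Methyl: Compound 4 Awaited

The source may hold more compounds than are shown below. What is called first, only, known or untested is meant among the compounds shown, and "the series" means these compounds.

Measured so far:
compound 1, `O=C(NCc1ccco1)c1ccccc1OCc1ccccc1`, 49000 nM
compound 2, `O=C(NC1CCCNC1)c1ccccc1OCc1ccccc1Cl`, > 100000 nM
compound 3, `Cc1ccccc1COc1ccccc1C(=O)Nc1cccnc1`, 1500 nM

All three were tested in an assay on lysate for inhibition of phosphatidylcholine:ceramide cholinephosphotransferase 2 (Homo sapiens), read by HPLC, with stated times of 30 min and 2 h; a higher number here means a weaker inhibitor, a lower number a stronger inhibitor. Compound 1 gives 49000 nM. For compound 2 the assay reports only (the limit of > 100000 nM in this assay, at which 1 of the 3 values shown sits), a limit and not a number. Compound 3 gives 1500 nM, the lowest of the two numbers available; its nearest neighbour is compound 1, and the gap between the two lies beyond the scatter. Compound 2 cannot be placed against them beyond its limit.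

Compound 4, `O=C(Nc1cccnc1)c1ccccc1OCc1c(Cl)cccc1Cl`, differs from compound 3 by 2,6-dichlorophenyl in place of 2-methylphenyl on a saturated chain carbon bound to an oxygen on an aromatic ring. Among the compounds with values here, no pair among the measured compounds isolates this change, so there is no measured step to lean on. The expected step from compound 3 to compound 4, no change at the digits printed from compound 3 to compound 4 (within the scatter), is taken to be small, in no firm direction, and likely within the scatter. Compound 4 is therefore estimated at 1500 nM, with a range from 300 nM to 8000 nM.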

Compound 4, half-maximal inhibitory concentration: 690 nM
Compound 4: middle estimate off by 2.2-fold (0.34 log units), on the high side, and the stated range covers the measured number.
By their numbers in this assay, from the lowest: compound 4; then compound 3; then compound 1. At a limit, above all of these: compound 2.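

In this assay, within the data shown here, replacing 2-methylphenyl with 2,6-dichlorophenyl on a saturated chain carbon bound to an oxygen on an aromatic ring gives a 2.2-fold lower number from compound 3 to compound 4 (0.34 log units; beyond the scatter), the first measured step that isolates a single place. It shows that this place accepts the 2,6-dichlorophenyl group, which has the same number of hydrogen-bond donors and acceptors as 2-methylphenyl, and that the exchange brings a modest gain rather than a loss. Nothing measured here explains why the number falls with this change.

The compounds shown leave open whether a phenyl ring with a single chlorine, or one carrying trifluoromethyl or a carboxylic acid, would match 2,6-dichlorophenyl here. They also leave open whether the same exchange would give a similar step on the core of compound 1.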